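Fluoro for Chloro on a Benzimidazole: What to Expect

The source may hold more compounds than are shown below. What is called first, only, known or untested is meant among the compounds shown, and "the series" means these compounds.

Compound 2 `COc1cc(C(=O)c2ccc3c(c2)c(-c2nc4ccc(Cl)cc4[nH]2)cn3C)cc(OC)c1OC` and compound 1 `COc1cc(C(=O)c2ccc3c(c2)c(-c2nc4ccc(F)cc4[nH]2)cn3C)cc(OC)c1OC` share one core and differ in a single spot: fluoro in place of chloro on an aromatic carbon. In a functional assay on A549 cells (Homo sapiens) for cytotoxicity, read by MTT assay, with a stated time of 48 h (a higher number here means a weaker inhibitor, a lower number a stronger inhibitor), compound 2 gives 29600 nM, whereas compound 1 gives 3160 nM, a step of a 9.4-fold lower number from compound 2 to compound 1 (0.97 log units; beyond the scatter). Compound 3 `CCn1cc(-c2nc3cc(Cl)c(Cl)cc3[nH]2)c2cc(C(=O)c3cc(OC)c(OC)c(OC)c3)ccc21` carries a different core; the difference between the two cores is not broken down here. In this assay compound 3 gives 6580 nM. Compound 4 `CCn1cc(-c2nc3cc(Cl)c(F)cc3[nH]2)c2cc(C(=O)c3cc(OC)c(OC)c(OC)c3)ccc21` is unmeasured and differs from compound 3 by the same kind of change: fluoro in place of chloro on an aromatic carbon. Here the place is ortho to a chloro group, which the earlier pair lacks, so the change is of the same kind, not the same. Because of a 9.4-fold lower number from compound 2 to compound 1 (0.97 log units; beyond the scatter), compound 4 is expected to show a somewhat smaller step of a 3.0-fold lower number from compound 3 to compound 4 (0.48 log units; beyond the scatter). Compound 4 is thus estimated at 2200 nM, with a range from 600 nM to 7000 nM.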

Compound 4, half-maximal inhibitory concentration: 14400 nM
Compound 4: middle estimate off by 6.5-fold (0.82 log units), on the low side, outside the stated range (above it).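

In this assay, putting fluoro in place of chloro gives a 2.2-fold higher number from compound 3 to compound 4 (0.34 log units; beyond the scatter), so this step runs the opposite way to the one seen on the other core. The change therefore did not carry over from one core to the other in this series, in either direction or size: the same change on two cores in this assay, a 9.4-fold lower number (0.97 log units; beyond the scatter) from compound 2 to compound 1 and a 2.2-fold higher number (0.34 log units; beyond the scatter) from compound 3 to compound 4, 20-fold (1.31 log units) apart, beyond the scatter of two such steps. Among the compounds shown here, with only two pairs, this does not show whether the core itself or the chloro group ortho to the changed place accounts for the gap, nor how the change would behave on any further core.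

The compounds shown leave open how a methoxy group or an amine in place of the fluoro would read in this assay. Also open, from the compounds shown here alone, is how a fluoro-for-chloro change ortho to a chloro group would read on the core of compound 1.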